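The compounds below may be only part of what the source reports. "The series", "measured", "known", "first", "only" and "open" are said of these compounds alone.

Compound 1, with the structure `COc1ccc2nc(C)cc(OCC(=O)Nc3cc(C)cc(C)c3)c2c1`, is the starting point of this step. In a toxicity assay on HepG2 cells (Homo sapiens) for inhibition, read by CellTiter-Glo, with a stated time of 48 h (a lower number here means a stronger inhibitor, a higher number a weaker inhibitor), compound 1 gives 20000 nM, the highest of the two numbers recorded there, with compound 2 as its nearest neighbour.

Compound 2, `COc1cc2nc(C)cc(OCC(=O)Nc3cc(C)cc(C)c3)c2cc1OC`, carries a methoxy in place of hydrogen on an aromatic carbon of the shared core; in this assay compound 2 gives 10000 nM. The step of a 2.0-fold lower number from compound 1 to compound 2 (0.30 log units; within the scatter) is too small to count as a real change.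

Compound 3, `Cc1cc(C)cc(NC(=O)COc2cc(C)nc3ccc(OCc4ccccc4)cc23)c1`, replaces a hydrogen with a phenyl on the saturated chain carbon bound to an oxygen on the aromatic ring. In this assay compound 3 reaches only > 100000 nM, which is a limit of the assay rather than a number. The step of an at least 5.0-fold higher number from compound 1 to compound 3 (0.69 log units; beyond the scatter) is at least modest, and the limit of > 100000 nM in this assay, at which 1 of the 3 values shown sits, marks where that value sits.

Compound 4, `COc1ccc2nc(C)cc(OCC(=O)Nc3ccccc3)c2c1`, differs from compound 1 at another place: phenyl in place of 3,5-dimethylphenyl on an amide-type nitrogen. Going by the values given here, neither measured step touches the amide-type nitrogen, so no step bears directly on this change. The expectation for compound 4 is therefore a step of no change at the digits printed from compound 1 to compound 4 (within the scatter), no change beyond the scatter. Compound 4 is estimated at 20000 nM, within 7000 nM to 60000 nM.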

Compound 4, half-maximal inhibitory concentration: 39800 nM
Estimate against measurement, compound 4: 2.0-fold (0.30 log units) below; the range from low to high includes it.
By their numbers in this assay, from the lowest: compounds 2, 1 and 4 (each within the scatter of the next, the first and the last beyond it). At a limit, above all of these: compound 3.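

Going by these compounds alone, compound 4 gives the first reading at the other end of the molecule, the ring on the amide-type nitrogen, since the earlier steps changed only the far side of the shared core. In this assay the exchange of 3,5-dimethylphenyl for phenyl gives a 2.0-fold higher number from compound 1 to compound 4 (0.30 log units; within the scatter) and so counts as no real change: at this place, losing the two methyl groups leaves no mark that can be told from the noise of repeated measurement. The only step so far beyond the scatter is still an at least 5.0-fold higher number from compound 1 to compound 3 (0.69 log units; beyond the scatter) on the other side of the molecule, and it rests on a limit of the assay, while nothing in the data shown gives a reason why the amide end behaves as it does here.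

As far as these compounds go, a single pair cannot show whether this place is tolerant in general, so it stays open whether an amine or a carboxylic acid on this ring, or a longer chain in place of the ring, would shift the number beyond the scatter. From the compounds shown here alone, it is also open whether the same exchange would read the same way on the core of compound 2 or of compound 3.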